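Replacing trifluoromethyl on the ether chain of compound 3

A few compounds are considered here, and "the series" means these few. Any claim that something is new, unique, unknown or untested is made for them only; others in the source may bear on it.

Of the compounds shown here, three sharing one core have been measured in an ADME assay (liver) for pharmacokinetics, with Liver microsome (Rattus norvegicus) as the target, read by LC-MS, using microsomes, tested at 2 uM (on this read-out lower numbers stand for slow clearance and higher numbers for fast clearance), and they differ only in the group on the oxygen on an aromatic ring. Compound 1 `O=C(N[C@@H]1CCCC[C@H]1O)c1cnc(Oc2ccccc2)c(-c2ccc(Cl)cc2)c1` gives 0.353 mL/min/kg, compound 2 `COCCOc1ncc(C(=O)N[C@@H]2CCCC[C@H]2O)cc1-c1ccc(Cl)cc1` gives 0.098 mL/min/kg, and compound 3 `O=C(N[C@@H]1CCCC[C@H]1O)c1cnc(OCC(F)(F)F)c(-c2ccc(Cl)cc2)c1` gives 0.023 mL/min/kg, the lowest of the three numbers.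

Compound 4 `Cc1cc(COc2ncc(C(=O)N[C@@H]3CCCC[C@H]3O)cc2-c2ccc(Cl)cc2)on1` has 3-methyl-1,2-oxazol-5-yl in place of trifluoromethyl on a saturated chain carbon bound to an oxygen on an aromatic ring. Cut one bond further out, this reads 2,2,2-trifluoroethoxy to (3-methyl-1,2-oxazol-5-yl)methoxy.

Among the compounds with values here, no measured compound carries this ring, so the evidence is indirect. The nearest comparison is a 4.3-fold lower number from compound 2 to compound 3 (0.63 log units; beyond the scatter), where trifluoromethyl replaced methoxymethyl at the same place. Two further steps show the range across these groups: a 3.6-fold lower number from compound 1 to compound 2 (0.56 log units; beyond the scatter) and a 15-fold lower number from compound 1 to compound 3 (1.19 log units; beyond the scatter). Both other groups give higher numbers than compound 3, and the one measured aromatic ring on the oxygen, in compound 1, gives the highest number at 0.353 mL/min/kg. A modest to large upward step is therefore expected in this assay, estimated as a 5.7-fold higher number from compound 3 to compound 4 (0.75 log units; beyond the scatter). Compound 4 is expected at about 0.13 mL/min/kg, within an estimated range of 0.04 mL/min/kg to 0.4 mL/min/kg.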

Compound 4, clearance: 0.151 mL/min/kg
For compound 4 the middle estimate is 1.2-fold (0.07 log units) below the measured one, within the range that was stated.
By their numbers in this assay, from the lowest: compound 3; then compounds 2 and 4 (each within the scatter of the next); then compound 1.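

In this assay, swapping trifluoromethyl for a ring at this place gives up most of what compound 3 had gained: a 6.6-fold higher number from compound 3 to compound 4 (0.82 log units; beyond the scatter), and compound 3 keeps the lowest number of the four. The first ring at this place also shows that the group on the saturated chain carbon need not be an open chain to reach the level of methoxymethyl, since a 1.5-fold higher number from compound 2 to compound 4 (0.19 log units; within the scatter) leaves 3-methyl-1,2-oxazol-5-yl and methoxymethyl not separable here. An aromatic ring held one carbon further out from the oxygen also differs from phenyl directly on that oxygen, with a 2.3-fold lower number from compound 1 to compound 4 (0.37 log units; beyond the scatter), so having an aromatic ring in this part of the molecule does not by itself give the number of compound 1.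

Nothing shown accounts for the distance between trifluoromethyl and the other groups at this place. On these data alone, it remains open whether the methyl on the 1,2-oxazole ring contributes to the number of compound 4, and whether a longer fluorinated chain such as 2,2,3,3,3-pentafluoropropyl, or a chain ending in an amine, would fall nearer compound 3 or nearer compound 4.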